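A few compounds are considered here, and "the series" means these few. Any claim that something is new, unique, unknown or untested is made for them only; others in the source may bear on it.

Measured in a functional assay on DU-145 cells (Homo sapiens) for inhibition, read by MTT assay, with a stated time of 48 h; a lower number here means a stronger inhibitor, a higher number a weaker inhibitor:
Compound 1 `CCn1c(/C=C2\SC(=O)N(CC(=O)N3CCc4cc(OC)c(OC)cc4C3)C2=O)nc2ccccc21`: > 50000 nM (a limit)
Compound 2 `COc1cc2c(cc1OC)CN(C(=O)CN1C(=O)S/C(=C\c3nc4ccccc4n3C(C)C)C1=O)CC2`: 29700 nM

Going by the values given here, compound 2 gives the only actual number so far, 29700 nM. Compound 1 reaches only a limit, > 50000 nM. The next compound, compound 3 `COc1cc2c(cc1OC)CN(C(=O)CN1C(=O)S/C(=C\c3nc4ccccc4n3C)C1=O)CC2`, changes one group: methyl in place of isopropyl on an aromatic nitrogen. This puts methyl in place of isopropyl on an aromatic nitrogen, next to the ring atom that bears a large group.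

Among the compounds with values here, one measured step concerns the group on this same aromatic nitrogen: an at least 1.6-fold lower number from compound 1 to compound 2 (0.22 log units; that floor lies within the scatter). It is a floor within the scatter, so it offers a hint rather than a trend. Going by that hint, the smaller group in compound 3 should move this assay toward a higher number, if at all, and the result may well be (the limit of > 50000 nM in this assay, at which 1 of the 2 values shown sits). The expected change is a 1.5-fold higher number from compound 2 to compound 3 (0.18 log units; within the scatter), a modest estimated step. Compound 3 is expected at about 45000 nM, with an estimated range of 20000 nM to 100000 nM.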

Compound 3, half-maximal inhibitory concentration: 37500 nM
Compound 3: middle estimate off by 1.2-fold (0.08 log units), on the high side; low and high end bracket the measured number.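

Going by these compounds alone, compound 3 gives the first comparison at this aromatic nitrogen between two actual numbers, and in this assay methyl and isopropyl cannot be told apart: the step is a 1.3-fold higher number from compound 2 to compound 3 (0.10 log units; within the scatter). The ethyl group of compound 1 adds little to this picture, as an at least 1.3-fold lower number from compound 1 to compound 3 (0.12 log units; that floor lies within the scatter) is only a floor, so the three groups form no order by chain size. Compound 1 holds a limit rather than a number, which is why its steps can only be floors: the limit of > 50000 nM in this assay, at which 1 of the 3 values shown sits.

The compounds shown carry only methyl, ethyl and isopropyl on this nitrogen. On these data alone, it stays open whether hydrogen, a benzyl group or a chain ending in an amine would shift the number beyond the usual scatter.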